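Iodo to butoxy in an antiproliferative series

A few compounds are considered here, and "the series" means these few. Any claim that something is new, unique, unknown or untested is made for them only; others in the source may bear on it.

In a functional assay on MCF7 cells (Homo sapiens) for antiproliferative activity, read by sulforhodamine B assay, with a stated time of 48 h (a higher number here means a weaker inhibitor, a lower number a stronger inhibitor), compound 1 `Cc1cccc(NS(=O)(=O)c2ccc(N3CCNC3=O)cc2)c1` gives 190 nM, compound 2 `O=C1NCCN1c1ccc(S(=O)(=O)Nc2ccc(I)cc2)cc1` gives 600 nM and compound 3 `O=C1NCCN1c1ccc(S(=O)(=O)Nc2ccc(F)c(F)c2)cc1` gives 620 nM. Compound 2 therefore has one close neighbour and one more distant one: the data show a 1.0-fold higher number from compound 2 to compound 3 (0.01 log units; within the scatter), and also a 3.2-fold higher number from compound 1 to compound 2 (0.50 log units; beyond the scatter).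

Compound 4 `CCCCOc1ccc(NS(=O)(=O)c2ccc(N3CCNC3=O)cc2)cc1` has butoxy in place of iodo on an aromatic carbon, para to a large group: butoxy in place of iodo on an aromatic carbon. For the measured compounds named here, none of the measured compounds carries butoxy, so the evidence is indirect. It comes from the other exchanges of the group on the sulfonamide nitrogen, of which the largest are modest: a 3.2-fold higher number from compound 1 to compound 2 (0.50 log units; beyond the scatter), and a 3.3-fold higher number from compound 1 to compound 3 (0.51 log units; beyond the scatter). These steps do not point to a direction for the new change, so no shift beyond the scatter is expected in this assay. The expected step is a 1.2-fold lower number from compound 2 to compound 4 (0.08 log units; within the scatter). For compound 4 the estimated value is 500 nM, with an expected range of 150 nM to 1600 nM.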

Compound 4, half-maximal inhibitory concentration: 870 nM
Beside the measured number, compound 4's estimate is 1.7-fold (0.24 log units) below it; the measured number falls inside the stated range.
By their numbers in this assay, from the lowest: compound 1; then compounds 2, 3 and 4 (each within the scatter of the next).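

In this assay, butoxy in place of iodo on an aromatic carbon, para to a large group, gives a 1.5-fold higher number from compound 2 to compound 4 (0.16 log units; within the scatter) and so does not move the number beyond the scatter. The earlier compounds shown here showed only exchanges of small aryl substituents on the sulfonamide nitrogen, whereas this result shows that an alkoxy chain carrying a hydrogen-bond acceptor can take the place of iodo at this position with no shift that can be told from the scatter. No measurement at hand explains this outcome.

From the compounds shown here alone, it remains open whether a shorter chain such as methoxy, a longer chain such as hexyloxy, or a group of another kind such as an amine or a carboxylic acid would behave in the same way here. Going by these compounds, it is also open what butoxy would do in place of the methyl group of compound 1.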